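Adding a Chloro Group to a Weak Vasopressin Binder

This account rests on a few compounds, and the source may have more. Where it says the series, first, only, none or still open, it means among the compounds named here.

Measured so far:
compound 1, `CCNc1ccc(C(=O)N2CCCCc3cc(Cl)ccc32)c(Cl)c1`: 5 nM
compound 2, `O=C(c1ccc(N2CCCC2)cc1Cl)N1CCCCc2ccccc21`: 9 nM
compound 3, `O=C(c1ccc(N2CCCC2)cc1)N1CCCCc2cc(Cl)ccc21`: 210 nM

All three compounds were tested in an assay on HeLa cells for binding affinity to Vasopressin V2 receptor (Homo sapiens); a higher number here means a weaker inhibitor, a lower number a stronger inhibitor. Compound 3 stands at the highest number of the three, and its distance from both compound 2 and compound 1 is well beyond the usual scatter of this assay, so it is clearly the weakest inhibitor among them. Compound 3 and compound 2 are mirror images in one respect: each carries a single chlorine, but on different rings of the shared core.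

Compound 4, `O=C(c1ccc(N2CCCC2)cc1Cl)N1CCCCc2cc(Cl)ccc21`, has not yet been measured. It differs from compound 3 in one place: chloro in place of hydrogen on an aromatic carbon. The result carries chlorine on both rings, much like compound 1.

Among the compounds with values here, since no measured pair here isolates exactly this change, the expectation rests on the whole picture. Compound 2 carries this same chloro group and gives 9 nM, and compound 1, with chlorine on both rings, gives 5 nM. On that basis compound 4 is expected to improve strongly over compound 3, with a step of an 18-fold lower number from compound 3 to compound 4 (1.24 log units; beyond the scatter). The estimate for compound 4 in this assay is 12 nM, with a likely range from 3 nM to 50 nM.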

Compound 4, half-maximal inhibitory concentration: 16 nM
Compound 4: the middle estimate sits 1.3-fold (0.12 log units) below what was measured; measured number inside the range.
By their numbers in this assay, from the lowest: compounds 1, 2 and 4 (each within the scatter of the next, the first and the last beyond it); then compound 3.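

In this assay the chloro group ortho to a large group and meta to the pyrrolidin-1-yl group proves decisive for compound 3, and adding this single atom gives a 13-fold lower number from compound 3 to compound 4 (1.12 log units; beyond the scatter) in a large step. The chlorine on the other ring of the shared core shows no such effect once the first chloro group is present: a 1.8-fold higher number from compound 2 to compound 4 (0.25 log units; within the scatter) stays within the scatter, so its contribution in this setting cannot be read. With both chlorines in place, the choice of amine matters only modestly, as pyrrolidin-1-yl in place of ethylamino gives a 3.2-fold higher number from compound 1 to compound 4 (0.51 log units; beyond the scatter) in a small loss, and nothing measured here explains any of these steps.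

As far as these compounds go, whether a fluorine, a methyl group or a methoxy group on the same aromatic carbon would bring a step as large as the chloro group remains open. From the compounds shown here alone, it is also open whether that chloro group would matter as much with ethylamino in place of pyrrolidin-1-yl, or with a morpholine or a piperidine there instead.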